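Halogen placement on the aryl arm of the series

The source may report more compounds than this note shows. Statements on the series, on what has been measured and on what is new or still open speak of the compounds shown alone.

Three compounds share one core. In a functional assay on the whole organism (plasma) with Mus musculus as the target, with a stated time of 15 days, at a dose of 10 mg/kg by the oral route (a lower number here means a weaker effect, a higher number a stronger effect of the compound at the dose given), compound 1 `Cc1ccc(/C=C2\SC(=O)N(Cc3ccc(C)cc3)C2=O)cc1` gives 16.3%, compound 2 `Cc1ccc(CN2C(=O)S/C(=C\c3ccccc3Cl)C2=O)cc1` gives 19.2% and compound 3 `Cc1ccc(CN2C(=O)S/C(=C\c3ccc(Cl)cc3)C2=O)cc1` gives 18.7%. Compound 3 sits second of the three numbers, with compound 2 nearest at a number 0.5 percentage points lower from compound 2 to compound 3 (within the scatter) and compound 1 furthest at a number 2.4 percentage points higher from compound 1 to compound 3 (within the scatter); all three lie within the scatter of each other, so no order among them is claimed.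

Compound 4 `Cc1ccc(CN2C(=O)S/C(=C\c3cccc(Br)c3)C2=O)cc1` is not yet measured in this assay. It differs from compound 3 by 3-bromophenyl in place of 4-chlorophenyl on a double-bonded chain carbon bound to a double-bonded ring carbon.

For the measured compounds named here, two measured steps bear on this change. Swapping the halogen position, from compound 2 to compound 3, gave a number 0.5 percentage points lower from compound 2 to compound 3 (within the scatter), and exchanging methyl for chloro, from compound 1 to compound 3, gave a number 2.4 percentage points higher from compound 1 to compound 3 (within the scatter). Both moves on the aryl arm, whether of the substituent or of its position, left this assay essentially unchanged. Going by the values given here, the move to bromine and to a new position has no direct precedent, but nothing in these three compounds suggests a response beyond the scatter.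

Compound 4 is therefore expected to give 18.5% in this assay, with a range of 8% to 29%. The expected step from compound 3 is a number 0.2 percentage points lower from compound 3 to compound 4 (within the scatter).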

Compound 4, a percentage reported as activity, at one dose (the size of the read-out at that dose, not a potency): 21.3%
Beside the measured number, compound 4's estimate is 2.8 percentage points below it, and the stated range covers the measured number.
By their numbers in this assay, from the lowest: compounds 1, 3, 2 and 4 (each within the scatter of the next).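

In this assay the exchange for 3-bromophenyl gives a number 2.6 percentage points higher from compound 3 to compound 4 (within the scatter) when 4-chlorophenyl leaves and a number 2.1 percentage points higher from compound 2 to compound 4 (within the scatter) when 2-chlorophenyl leaves, so bromine at this new ring position stands within the scatter of both chloro compounds. The widest gap in the set, a number 5 percentage points higher from compound 1 to compound 4 (within the scatter) on replacing 4-methylphenyl, also stays within the scatter, so the earlier flat picture now holds across methyl, chloro and bromo aryl arms and no order among the four compounds is claimed. On a double-bonded chain carbon bound to a double-bonded ring carbon, these four aryl groups therefore give no separable difference in this read-out, and no supporting data speak to why it stays flat.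

Open, on these data alone, is whether an aryl arm carrying an amine or a carboxylic acid, in place of a halogen or methyl, would move the read-out beyond the scatter. Also open is whether a change elsewhere on the shared core would separate compounds, as every step shown stays on this arm and at a single dose.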